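This account rests on a few compounds, and the source may have more. Where it says the series, first, only, none or still open, it means among the compounds named here.

Working notes on the series. Four compounds share one core and differ at one nitrogen on an aromatic ring or in the drawn configuration of the core. Compound 2 `O=C(/C=C/c1cccc(NC(=O)Nc2ccccc2)c1)C[C@@H]1O[C@H](CO)[C@@H](O)[C@H](O)[C@H]1O` and compound 1 `Cc1ccc(S(=O)(=O)Nc2cccc(/C=C/C(=O)C[C@@H]3O[C@H](CO)[C@@H](O)[C@H](O)[C@H]3O)c2)cc1` carry measured values; compound 3 `O=C(/C=C/c1cccc(NC(=O)Nc2ccccc2)c1)C[C@@H]1O[C@H](CO)[C@@H](O)[C@H](O)[C@@H]1O` and compound 4 `Cc1ccc(S(=O)(=O)Nc2cccc(/C=C/C(=O)C[C@@H]3O[C@H](CO)[C@@H](O)[C@H](O)[C@@H]3O)c2)cc1` complete the set, and compound 4 remains to be tested.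

In an ADME assay on Vero cells (Chlorocebus sabaeus) for cytotoxicity, read by resazurin assay, with a stated time of 2 days (a higher number here means that more compound is tolerated, a lower number that less compound is tolerated), compound 2 gives 373000 nM. In this assay compound 1 gives 381000 nM. The change from compound 2 to compound 1 is (4-methylphenyl)sulfonyl in place of phenylcarbamoyl on a nitrogen on an aromatic ring. The step made by that change is a 1.0-fold higher number from compound 2 to compound 1 (0.01 log units; within the scatter), so the two values are to be read as one level of tolerated compound.

In this assay compound 3 gives "not determined" (no result reported), so no single number stands for it. Compound 3 and compound 2 differ as follows: the two compounds have the same atoms and bonds and differ only in configuration as drawn: 1 of 6 stereo elements differ; a stereocentre at a saturated ring carbon is drawn R in compound 2 and S in compound 3. Going by the values given here, this is what the fact that compounds 2 and 3 differ only in the configuration as drawn holds; no measured step attaches to it.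

The same kind of change is made from compound 3 to compound 4: (4-methylphenyl)sulfonyl in place of phenylcarbamoyl on a nitrogen on an aromatic ring. The place lines of the two changes agree word for word, and the groups leaving and entering are the same.

With compound 3 unmeasured, the expectation for compound 4 rests on the measured pair, because a 1.0-fold higher number from compound 2 to compound 1 (0.01 log units; within the scatter) lay within the scatter. Compound 4 is therefore expected in this assay near 380000 nM, with a likely span from 190000 nM to 760000 nM.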

Compound 4, half-maximal cytotoxic concentration: 417000 nM
Compound 4: the middle estimate sits 1.1-fold (0.04 log units) below what was measured, and the stated range covers the measured number.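

In this assay, a 1.1-fold higher number from compound 1 to compound 4 (0.04 log units; within the scatter), so with the (4-methylphenyl)sulfonyl group in place the two cores stand at one level of tolerated compound, and this pair differs in one respect only: the fact that compounds 1 and 4 differ only in the configuration as drawn. Compound 3 has no number, so neither the step from compound 2 to compound 3 nor the step from compound 3 to compound 4 can be read, and the exchange of phenylcarbamoyl for (4-methylphenyl)sulfonyl has a measured size on the core of compound 2 only. The level of compound 4 is compatible with the exchange carrying over to its core without a visible step, but it does not show this, as the starting value on that core is missing, and for the phenylcarbamoyl pair only the structural relation stands: the fact that compounds 2 and 3 differ only in the configuration as drawn.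

Still open is how the level in this assay would respond to a free amine, an acetyl group or a longer alkyl chain on a nitrogen on an aromatic ring, since the compounds shown carry only phenylcarbamoyl and (4-methylphenyl)sulfonyl there. Going by these compounds alone, also open is whether any group at that place would make the drawn configuration matter, as the one readable configuration pair shows no step beyond the scatter.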